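Fluoro-for-hydrogen step across two cores

The compounds below may be only part of what the source reports. "The series", "measured", "known", "first", "only" and "open" are said of these compounds alone.

Measured so far:
Compound 1, `O=C1/C(=C/c2ccccc2)CCc2ccccc21`, 32400 nM
Compound 2, `O=C1/C(=C/c2cccc(F)c2)CCc2ccccc21`, 11900 nM
Compound 3, `O=C1CCCCC/C1=C\c1ccccc1`, 215000 nM

All values come from a functional assay on MOLT-4 cells (Homo sapiens) for inhibition; a higher number here means a weaker inhibitor, a lower number a stronger inhibitor. Compound 1 and compound 2 share a core and differ only by fluoro in place of hydrogen on an aromatic carbon; this step is a 2.7-fold lower number from compound 1 to compound 2 (0.43 log units; beyond the scatter). Compound 3 carries a different core; the difference between the two cores is not broken down here, and in this assay compound 3 gives the highest number of the three.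

Compound 4, `O=C1CCCCC/C1=C\c1cccc(F)c1`, is not yet measured. It differs from compound 3 by fluoro in place of hydrogen on an aromatic carbon. This is the same kind of change as that from compound 1 to compound 2, though the place is given there as meta to a large group and here as meta to a group of 9 heavy atoms. Compound 4 is expected to follow the earlier step, giving an estimated 2.5-fold lower number from compound 3 to compound 4 (0.40 log units; beyond the scatter), because compound 3 starts from 215000 nM and the earlier change gave a 2.7-fold lower number from compound 1 to compound 2 (0.43 log units; beyond the scatter). The estimate for compound 4 is 85000 nM, expected between 35000 nM and 200000 nM.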

Compound 4, half-maximal inhibitory concentration: 482000 nM
Estimate against measurement, compound 4: 5.7-fold (0.75 log units) below, and the stated range ends below it.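

In this assay, fluoro in place of hydrogen on an aromatic carbon gives a 2.2-fold higher number from compound 3 to compound 4 (0.35 log units; beyond the scatter), opposite in direction to the step on the core of compound 1. The change therefore does not carry over from one core to the other in this series, and the two steps are clearly different: the same change on two cores in this assay, a 2.7-fold lower number (0.43 log units; beyond the scatter) from compound 1 to compound 2 and a 2.2-fold higher number (0.35 log units; beyond the scatter) from compound 3 to compound 4, 6.1-fold (0.79 log units) apart, beyond the scatter of two such steps. This rests on a single pair per core, and it does not show which part of the cores accounts for the difference, nor whether the opposite direction would hold for other pairs on these cores.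

On these data alone, it remains open whether chloro, methoxy or an amine on the same aromatic carbon would split between the two cores in the same way. Also open, as far as these compounds go, is whether any other core would follow compound 2 or compound 4.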